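The compounds below may be only part of what the source reports. "The series", "measured", "known", "first", "only" and "open" are said of these compounds alone.

Three close relatives sharing one core have been tested in a functional assay on Ramos cells (Homo sapiens) for cytotoxicity, read by CCK-8 assay, with a stated time of 72 h; a lower number here means a stronger inhibitor, a higher number a weaker inhibitor. Compound 1 `Cn1cc(NC(=O)c2ncn3ccc(N4CCC[C@@H](N)C4)nc23)c(C(F)F)n1` reaches only a limit of the assay, > 50000 nM. Compound 2 `Cn1cc(NC(=O)c2cnc3ccc(N4CCC[C@@H](N)C4)nn23)c(C(F)F)n1` gives a number, 44300 nM, which is still a very weak inhibition. Compound 3 `Cn1cc(NC(=O)c2cnc3ccc(N[C@H]4CCCNC4)nn23)c(C(F)F)n1` again reaches only a limit, > 50000 nM. For the measured compounds named here, the single step that can be measured, an at least 1.1-fold higher number from compound 2 to compound 3 (0.05 log units; that floor lies within the scatter), runs from a weak number to the ceiling of the assay, so compound 3 sits where the method stops counting, with the limit of > 50000 nM in this assay, at which 2 of the 3 values shown sit, as the common mark of that ceiling.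

Compound 4 `Cn1cc(NC(=O)c2cnc3ccc(NCCN)nn23)c(C(F)F)n1` differs from compound 3 in one place: 2-aminoethyl in place of piperidin-3-yl on a nitrogen on an aromatic ring. Cut one bond further out, the same difference reads (piperidin-3-yl)amino to (2-aminoethyl)amino. Going by the values given here, no measured step in this set swaps a ring for an open chain, and the one step that exists touches the same region but is tiny and lies within the scatter. With compound 3 already at a limit and compound 1 also at a limit, no movement beyond the scatter is expected, and the step of a number no higher from compound 3 to compound 4 (the limit leaves the size open) is estimated to be flat. Compound 4 is therefore expected to give about 50000 nM, within a range from 20000 nM to 150000 nM, most probably again as a limit rather than a number.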

Compound 4, half-maximal inhibitory concentration: > 50000 nM
Compound 4: no number, only a limit; the forecaster's own chance of this, stated with the estimate: 80%; the middle value lies on the limit itself.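

In this assay, replacing the piperidin-3-yl ring with the open 2-aminoethyl chain on a nitrogen on an aromatic ring brings no visible strengthening: compound 3 and compound 4 both stop at a limit, and the step between them cannot be read. For the compounds shown here, the one step that can be read, an at least 1.1-fold higher number from compound 2 to compound 4 (0.05 log units; that floor lies within the scatter), gives only a floor and shows no measurable gain from putting (2-aminoethyl)amino in place of 3-aminopiperidin-1-yl on an aromatic carbon. Removing the ring, and with it the defined stereocentre, therefore does not bring this compound down from the ceiling of the method, which now holds most of the set: the limit of > 50000 nM in this assay, at which 3 of the 4 values shown sit.

From the compounds shown here alone, how far compound 3 and compound 4 lie past the limit remains unknown, and so does any true order between the ring and the chain. Also open, going by these compounds, is whether a longer chain such as 3-aminopropyl, or a carboxylic acid in place of the terminal amine, would give a readable number at this nitrogen.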